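The source may report more compounds than this note shows. Statements on the series, on what has been measured and on what is new or still open speak of the compounds shown alone.

Of the compounds shown here, three have been tested in a functional assay on the whole organism (strain albino) for inhibition, with Rattus norvegicus as the target, read by paw edema, with stated times of 30 min and 3 h, at a dose of 0.28 mmol/kg by the oral route; a lower number here means less inhibition, a higher number more inhibition at the dose given (going by the name of the read-out). Compound 1, `COc1cc(-c2nnc(SCC(=O)Nc3ccc(/C(C)=N/O)cc3)n2-c2ccccc2)cc(OC)c1OC`, gives 66%. Compound 2, `CCn1c(SCC(=O)Nc2ccc(/C(C)=N/O)cc2)nnc1-c1cc(OC)c(OC)c(OC)c1`, gives 70%. Compound 3, `CCn1c(SCC(=O)Nc2ccc(C(C)=O)cc2)nnc1-c1ccccc1`, gives 56%. Compounds 1 and 2 differ only by phenyl in place of ethyl on an aromatic nitrogen, and that change made a step of a number 4 percentage points lower from compound 2 to compound 1 (within the scatter). The difference between the cores of compound 2 and compound 3 is not broken down here.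

Compound 4, `CC(=O)c1ccc(NC(=O)CSc2nnc(-c3ccccc3)n2-c2ccccc2)cc1`, has not yet been measured in this assay. It differs from compound 3 by phenyl in place of ethyl on an aromatic nitrogen. This is the same kind of change as that from compound 2 to compound 1, though the surroundings differ: in compound 2 the ring nitrogen sits next to two ring atoms that each bear a large group, while in compound 3 it sits next to the ring atom that bears a large group and next to the ring atom that bears a phenyl group. Because the earlier step was a number 4 percentage points lower from compound 2 to compound 1 (within the scatter), a step of about a number 2 percentage points lower from compound 3 to compound 4 (within the scatter) is expected here as well. Compound 4 is therefore estimated to give 54%, likely between 42% and 66%.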

Compound 4, a percentage reported as inhibition, in the whole organism at one dose (the size of the read-out at that dose, not a potency): 62%
For compound 4 the middle estimate is 8 percentage points below the measured one; measured number inside the range.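

In this assay, putting phenyl in place of ethyl on the aromatic nitrogen of the core of compound 3 gave a step of a number 6 percentage points higher from compound 3 to compound 4 (within the scatter). Set beside the same change on the other core, the two steps do not differ by more than the scatter allows: the same change on two cores in this assay, a number 4 percentage points lower (within the scatter) from compound 2 to compound 1 and a number 6 percentage points higher (within the scatter) from compound 3 to compound 4, 10 percentage points apart, within the scatter of two such steps. This shows that, on these two cores, the change left the number within the scatter, and that no difference between the cores can be claimed; it does not show that the change has no effect at all, that it has a direction, or that it would behave the same way on any other core in the series.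

The compounds shown carry only ethyl or phenyl on that nitrogen, so it stays open whether a methyl group, a longer chain such as butyl, or a benzyl group there would move the number beyond the scatter. Also open, as far as these compounds go, is what each of the other differences between the two cores does when taken on its own.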